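The source may report more compounds than this note shows. Statements on the series, on what has been measured and on what is new or still open speak of the compounds shown alone.

Compound 1 `COc1cc(/C=C2\CN(C)C/C(=C\c3ccc(Cl)c(Cl)c3)C2=O)cc(OC)c1`: 9490 nM
Compound 2 `COc1cc(/C=C2\CN(C)C/C(=C\c3cccc([N+](=O)[O-])c3)C2=O)cc(OC)c1`: 4420 nM

In a functional assay on K562 cells (Homo sapiens) for cytotoxicity, read by MTT assay, with a stated time of 24 h (on this read-out higher numbers stand for weaker inhibition and lower numbers for stronger inhibition), compound 2 gives the lower of the two numbers. Going by the values given here, the only measured step bears directly on what comes next: a 2.1-fold lower number from compound 1 to compound 2 (0.33 log units; beyond the scatter). It swapped one substituted phenyl group for another at the same place and moved the number modestly. Compound 3 `COc1cc(/C=C2\CN(C)C/C(=C\c3ccc(C#N)cc3)C2=O)cc(OC)c1` makes a similar swap: 4-cyanophenyl in place of 3-nitrophenyl on a double-bonded chain carbon bound to a double-bonded ring carbon. In words, 4-cyanophenyl stands in place of 3-nitrophenyl on a double-bonded chain carbon bound to a double-bonded ring carbon. A single modest step shows no direction for this new group, so no step beyond the scatter is expected in this assay, though a step of similar size either way would be unsurprising. The expected outcome is a 1.1-fold higher number from compound 2 to compound 3 (0.05 log units; within the scatter). For compound 3 the estimate is 5000 nM, with an expected range from 2000 nM to 12000 nM.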

Compound 3, half-maximal inhibitory concentration: 4650 nM
Compound 3: middle estimate off by 1.1-fold (0.03 log units), on the high side; the range from low to high includes it.
By their numbers in this assay, from the lowest: compounds 2 and 3 (each within the scatter of the next); then compound 1.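

In this assay, 4-cyanophenyl in place of 3-nitrophenyl gives a 1.1-fold higher number from compound 2 to compound 3 (0.02 log units; within the scatter), so these two groups cannot be told apart at this position. Measured against 3,4-dichlorophenyl, the new group gives a 2.0-fold lower number from compound 1 to compound 3 (0.31 log units; beyond the scatter), so the lower number seen with 3-nitrophenyl does not need a nitro group: a ring carrying a nitrile reaches the same level. No measurement here explains why these two groups match or why 3,4-dichlorophenyl gives the higher number.

Still open, as far as these compounds go, is what a plain unsubstituted phenyl would give at this position, which would show whether any substituent on the ring matters. A 4-aminophenyl or a 4-carboxyphenyl ring would also test whether the number stays at this level with quite different atoms in place.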